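Chloro in Place of the Aryloxy Group on the Core

The source may report more compounds than this note shows. Statements on the series, on what has been measured and on what is new or still open speak of the compounds shown alone.

Compound 3 `Cc1cccc(Oc2c(/C=N/OCc3snnc3C)c(C)nn2C)c1` stands at the edge of what the numbers show: in a functional assay on Huh-7 cells (Homo sapiens) for inhibition, read by MTT assay, with a stated time of 48 h (a higher number here means a weaker inhibitor, a lower number a stronger inhibitor), compound 3 gives > 50000 nM, which is a limit of the assay and not a number. Compound 2 `Cc1nnsc1CO/N=C/c1c(C)nn(C)c1Oc1ccc(I)cc1` likewise gives > 50000 nM in this assay, again a limit. Compound 1 `Cc1nnsc1CO/N=C/c1c(C)nn(C)c1Oc1ccc(Br)cc1` gives 11800 nM in this assay, and an at least 4.2-fold higher number from compound 1 to compound 3 (0.62 log units; beyond the scatter), while a step that the two limits leave unreadable from compound 2 to compound 3. Compound 4 `Cc1nnsc1CO/N=C/c1c(C)nn(C)c1Cl` differs from compound 3 in that (chloro in place of 3-methylphenoxy on an aromatic carbon). Within the data shown here, no measured step exchanges the aryloxy group for a halogen, and two of the three values sit at the limit of > 50000 nM in this assay, at which 2 of the 3 values shown sit, so the size of the coming step cannot be read from the measured ones. Compound 4 is therefore expected near 50000 nM, between 15000 nM and 150000 nM, in this assay, with the estimated step of a number no higher from compound 3 to compound 4 (the limit leaves the size open) not clearly beyond the scatter.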

Compound 4, half-maximal inhibitory concentration: > 50000 nM
Compound 4 ended at the assay's limit; the forecaster's own chance of this, stated with the estimate: 60%; the middle value sits exactly at the limit.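

In this assay, among these compounds, chloro in place of 4-bromophenoxy on an aromatic carbon gives an at least 4.2-fold higher number from compound 1 to compound 4 (0.62 log units; beyond the scatter), so the first change to the whole aryloxy group, which removes its aromatic ring, leaves no readable value. The steps from compound 2 and from compound 3 to compound 4 cannot be read, as both ends of each are limits. Among the compounds shown, only the 4-bromophenoxy group gives a number, and the rest are capped: the limit of > 50000 nM in this assay, at which 3 of the 4 values shown sit.

Going by these compounds, how far compound 4 lies past its limit stays open. So does whether an amine or a longer alkoxy chain on this aromatic carbon would give a readable value.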